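Ethyl for bromo on the cinnamoyl-type aryl ring of compound 1

This account rests on a few compounds, and the source may have more. Where it says the series, first, only, none or still open, it means among the compounds named here.

Measured compounds:
compound 1, `O=C(/C=C/c1ccc(Br)cc1)c1ccc(-n2ccnc2)cc1`: 320 nM
compound 2, `O=C(/C=C/c1ccccc1F)c1ccc(-n2ccnc2)cc1`: > 10000 nM

In an assay on isolated protein for inhibition of Amine oxidase [flavin-containing] B (Homo sapiens) (a higher number here means a weaker inhibitor, a lower number a stronger inhibitor), compound 1 gives 320 nM, the only number reported among the two compounds shown. Compound 2, `O=C(/C=C/c1ccccc1F)c1ccc(-n2ccnc2)cc1`, reaches only (the limit of > 10000 nM in this assay, at which 1 of the 2 values shown sits), a limit of the assay rather than a number.

Going by the values given here, the one measured step, an at least 31-fold higher number from compound 1 to compound 2 (1.49 log units; beyond the scatter), changes both the substituent and its position on the ring at once, and is the only evidence in this assay. It does not address the change from compound 1 to compound 3, `CCc1ccc(/C=C/C(=O)c2ccc(-n3ccnc3)cc2)cc1`, which is ethyl in place of bromo on an aromatic carbon.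

Among the compounds with values here, no measured step touches this position with the same kind of change. The estimate for compound 3 therefore rests on compound 1 alone. The group swapped keeps the same position on the ring and leaves the rest of the molecule untouched, so the step of a 1.6-fold higher number from compound 1 to compound 3 (0.19 log units; within the scatter) is expected to stay small, with wide uncertainty. Compound 3 is therefore expected to give about 500 nM in this assay, within a range from 150 nM to 2500 nM.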

Compound 3, half-maximal inhibitory concentration: 320 nM
The estimate for compound 3 lay 1.6-fold (0.19 log units) above the measured number, within the range that was stated.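

In this assay, the exchange of bromo for ethyl on the aromatic carbon para to a large group gives no change at the digits printed from compound 1 to compound 3 (within the scatter). Compound 1 alone could not show whether bromo itself was required at this place, and compound 3 shows that a group with no halogen, ethyl with its 2 carbon atoms, serves equally well here in this assay, so the value does not depend on bromine being present among these two compounds. Nothing shown gives a reason for this equality.

The drop seen with compound 2, which gives > 10000 nM, a limit of the assay and not a number, remains unassigned, since an at least 31-fold higher number from compound 1 to compound 2 (1.49 log units; beyond the scatter) changes the substituent and its place on the ring in one step, and the compounds shown do not separate the two. Also open, going by these compounds, is how far this tolerance at the position extends, for instance to a longer chain such as butyl, to a methoxy group, or to an amine or a carboxylic acid in place of the ethyl.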